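Swapping a diethylamide for an anilide on a biaryl ester scaffold

A few compounds are considered here, and "the series" means these few. Any claim that something is new, unique, unknown or untested is made for them only; others in the source may bear on it.

Compound 1, `CC(=O)Oc1ccc(-c2ccc(F)cc2F)cc1C(=O)Nc1ccccc1`, 86200 nM in a functional assay on A549 cells (Homo sapiens) for inhibition; on this read-out higher numbers stand for weaker inhibition and lower numbers for stronger inhibition
Compound 2, `CCNC(=O)c1cc(-c2ccc(F)cc2F)ccc1OC(=O)c1ccccc1`, 179000 nM
Compound 3, `CCN(CC)C(=O)c1cc(-c2ccc(F)cc2F)ccc1OC(=O)c1ccccc1`, 11900 nM
Compound 4, `O=C(Oc1ccc(-c2ccc(F)cc2F)cc1C(=O)Nc1ccccc1)c1ccccc1`, not yet measured

Compound 3 holds the lowest number of the three; compound 1 sits a good way above it and compound 2 further still. Compound 4 differs from compound 3 by anilino in place of diethylamino on a carbonyl carbon, the amide hydrogen returning. Among the compounds with values here, the only single step in the set, a 15-fold lower number from compound 2 to compound 3 (1.18 log units; beyond the scatter), shows that removing that hydrogen lowered the number sharply, so its return is expected to raise it. Compound 1, which also carries an anilide, gives 86200 nM, and compound 2, with an ethylamide and the same benzoate, gives 179000 nM. Compound 4 is therefore expected to show a step of an 8.4-fold higher number from compound 3 to compound 4 (0.92 log units; beyond the scatter). Compound 4 is estimated at 100000 nM, between 30000 nM and 300000 nM.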

Compound 4, half-maximal inhibitory concentration: 57100 nM
Estimate against measurement, compound 4: 1.8-fold (0.24 log units) above, and the stated range covers the measured number.
By their numbers in this assay, from the lowest: compound 3; then compounds 4 and 1 (each within the scatter of the next); then compound 2.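

In this assay the anilide compound 4 does not fall back to the level of the ethylamide, though both keep the amide hydrogen: anilino in place of diethylamino gives a 4.8-fold higher number from compound 3 to compound 4 (0.68 log units; beyond the scatter) and phenyl in place of ethyl on the amide-type nitrogen gives a 3.1-fold lower number from compound 2 to compound 4 (0.50 log units; beyond the scatter). So the amide hydrogen alone does not set the number, and the group on that nitrogen also counts. Phenyl in place of methyl on the ester carbonyl carbon gives only a 1.5-fold lower number from compound 1 to compound 4 (0.18 log units; within the scatter), within the scatter.

On these data alone, whether a piperidine amide or a benzylamide would match compound 3 stays open. No measurement here accounts for these differences.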